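The source may report more compounds than this note shows. Statements on the series, on what has been measured and on what is new or still open speak of the compounds shown alone.

Among the compounds with values here, compound 2, with the structure `CC(NC(=O)c1ccc(-c2ccc(NC(=O)Nc3cc(C(F)(F)F)ccc3Cl)cc2)cc1)c1ccccc1`, is the only compound here with a numerical result: in a functional assay on A-375 cells (Homo sapiens) for inhibition, read by MTT assay, with a stated time of 120 h (on this read-out lower numbers stand for stronger inhibition and higher numbers for weaker inhibition), compound 2 gives 16900 nM. Compound 1, with the structure `CC1CN(C(=O)c2ccc(-c3ccc(NC(=O)Nc4ccc(Cl)c(C(F)(F)F)c4)cc3)cc2)CC(C)O1`, stands apart because in this assay compound 1 gives only > 50000 nM, which is a limit of the assay and not a number; this is the situation described by the limit of > 50000 nM in this assay, at which 1 of the 2 values shown sits. Within the data shown here, no step between two measured compounds can be drawn from these two results.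

Compound 3, with the structure `CC1CN(C(=O)c2ccc(-c3ccc(NC(=O)Nc4cc(C(F)(F)F)ccc4Cl)cc3)cc2)CC(C)O1`, has not yet been measured. Its structure follows from compound 2 by one change: 2,6-dimethylmorpholin-4-yl in place of (1-phenylethyl)amino on a carbonyl carbon. The carbonyl that carried the (1-phenylethyl)amino group now carries the ring instead, so one hydrogen-bond donor is lost and one acceptor is gained, as counted above.

With no measured step to lean on, the expectation rests on the spread of the two results shown. For compound 3 a weaker result than compound 2 is expected, with the step from compound 2 to compound 3 estimated at a 2.1-fold higher number from compound 2 to compound 3 (0.32 log units; beyond the scatter) in this assay. The estimate for compound 3 in this assay is 35000 nM, within a range from 10000 nM to 100000 nM.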

Compound 3, half-maximal inhibitory concentration: > 50000 nM
Compound 3: a limit, no number (the forecaster's own chance of this, stated with the estimate: 40%); at least 1.4-fold (0.15 log units) between middle value and limit.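

In this assay, within the data shown here, the carbonyl carbon gives the first single change that can be read, and 2,6-dimethylmorpholin-4-yl in place of (1-phenylethyl)amino brings an at least 2.9-fold higher number from compound 2 to compound 3 (0.47 log units; beyond the scatter). Compound 3 gives > 50000 nM, which is a limit of the assay and not a number, so this step has a known minimum size but no known full size. The step from compound 1 to compound 3, which swaps 4-chloro-3-(trifluoromethyl)phenyl for 2-chloro-5-(trifluoromethyl)phenyl, cannot be read, because both compounds sit at the same limit: the limit of > 50000 nM in this assay, at which 2 of the 3 values shown sit.

The change from compound 2 to compound 3 alters several things at once, as it removes the aromatic ring and the amide hydrogen and brings in a ring with oxygen, so the compounds shown cannot say which of these accounts for the step. As far as these compounds go, a benzylamino group on the same carbonyl carbon would keep the aromatic ring and the amide hydrogen, whereas a piperidin-1-yl group would keep a non-aromatic ring without the ring oxygen, and how either compares with compound 2 remains open.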